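This account rests on a few compounds, and the source may have more. Where it says the series, first, only, none or still open, it means among the compounds named here.

Measured compounds:
compound 1 `CN(C)C(=O)OCCC1=C(N2CC2)C(=O)C(CCOC(=O)N(C)C)=C(N2CC2)C1=O`: 4.85
compound 2 `CCC1=C(N2CC2)C(=O)C(CC)=C(N2CC2)C1=O`: 5.09

Both numbers come from a functional assay on L1210 cells (Mus musculus), with a stated time of 12 days; on this read-out lower numbers stand for lower potency and higher numbers for higher potency (the scale is a negative logarithm). In this assay compound 1 gives 4.85 and compound 2 gives 5.09; the gap between them lies within the usual scatter of repeated measurements, so neither can be called the more potent of the two. Compound 2 carries an ethyl group twice on the shared core, compound 1 a longer chain ending in a carbamate at both places.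

Compound 3 `CCC1=C(N2CC2)C(=O)C(C(COC(N)=O)OC)=C(N2CC2)C1=O` is not yet measured. It differs from compound 2 in one place: a group of 8 heavy atoms (4 carbon, 1 nitrogen, 3 oxygen; no ring) in place of a group of 2 heavy atoms (2 carbon; no ring), on a double-bonded ring carbon. Going by the values given here, no step between measured compounds that differ in one place is available. Among the compounds with values here, the only comparison, compound 1 against compound 2, shows carbamate-bearing chains in place of ethyl without a change beyond the scatter. For compound 3 the expected step is therefore a number 0.09 log units lower from compound 2 to compound 3 (within the scatter), that is, none beyond the scatter. In this assay compound 3 is expected to give about 5, with a range from 4.5 to 5.6.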

Compound 3, logarithm of the reciprocal of the active concentration, log(1/C): 5.22
The estimate for compound 3 lay 0.22 log units below the measured number, and the stated range covers the measured number.
By their numbers in this assay, from the lowest: compounds 1, 2 and 3 (each within the scatter of the next, the first and the last beyond it).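

In this assay the single-place step is a number 0.13 log units higher from compound 2 to compound 3 (within the scatter), so compound 2 and compound 3 cannot be told apart on this read-out. Going by these compounds alone, this is the first comparison confined to one place: on this double-bonded ring carbon, a group of 8 heavy atoms with 1 hydrogen-bond donor and 3 hydrogen-bond acceptors stands in place of ethyl, which has neither, with no difference beyond the scatter. No supporting measurement bears on this result.

On these data alone, whether an amine, a carboxylic acid or a simple longer alkyl chain on this ring carbon would move the number beyond the scatter remains open. Also open, as far as these compounds go, is how the methoxy and carbamate parts of the entering group would each read if present alone.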